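The source may report more compounds than this note shows. Statements on the series, on what has been measured and on what is new or still open speak of the compounds shown alone.

Two compounds share the core of compound 1 `CC(C)[C@H](C[C@H]1OC(=O)NC1=O)c1ccc(-c2ccc3cccc(F)c3c2)[nH]c1=O` and compound 2 `CC(C)[C@H](C[C@H]1SC(=O)NC1=O)c1ccc(-c2ccc3cccc(F)c3c2)[nH]c1=O`, and both have been tested in a functional assay on CHO cells for antagonist activity at prostaglandin E2 receptor EP3 subtype (Homo sapiens), read by cAMP accumulation, with a stated time of 30 min; on this read-out higher numbers stand for weaker inhibition and lower numbers for stronger inhibition. In that assay compound 1 gives 15 nM, and compound 2 gives 9 nM. For the measured compounds named here, the one step between them, a 1.7-fold lower number from compound 1 to compound 2 (0.22 log units; within the scatter), is the exchange of the oxazolidinedione ring for the thiazolidinedione ring. On the numbers shown compound 2 stands lowest of the two, with compound 1 as its nearest neighbour, but the gap between them lies within the scatter, so no order can be read from it.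

Compound 3 `CC(C)[C@@H](C[C@H]1SC(=O)NC1=O)c1ccc(-c2ccc3cccc(F)c3c2)[nH]c1=O` differs from compound 2 in this way: the two compounds have the same atoms and bonds and differ only in configuration as drawn: 1 of 2 stereo elements differ; a stereocentre at a saturated chain carbon is drawn S in compound 2 and R in compound 3. Going by the values given here, no measured step in this pair concerns a change of configuration; the only step known, from compound 1 to compound 2, alters a ring and not a stereocentre, and was itself within the scatter. Nothing here therefore fixes the size or direction of the step to compound 3. The account estimates that compound 3 gives 60 nM in this assay, a step of a 6.7-fold higher number from compound 2 to compound 3 (0.82 log units; beyond the scatter), with an expected range from 7 nM to 500 nM.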

Compound 3, half-maximal inhibitory concentration in the prostaglandin E2 receptor EP3 subtype assay: 17 nM
Estimate against measurement, compound 3: 3.5-fold (0.55 log units) above; the range from low to high includes it.
By their numbers in the prostaglandin E2 receptor EP3 subtype assay, from the lowest: compounds 2, 1 and 3 (each within the scatter of the next).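

In the prostaglandin E2 receptor EP3 subtype assay the configuration at the saturated chain carbon does not separate the two thiazolidinedione compounds, with a 1.9-fold higher number from compound 2 to compound 3 (0.28 log units; within the scatter), so drawing this stereocentre S or R has no readable effect on inhibition in this pair. In a physicochemical assay for solubility, measured as kinetic solubility, at pH 2 (a lower number here means a less soluble compound, a higher number a more soluble compound), however, compound 2 gives 4900 nM and compound 3 gives 12200 nM, so the same pair does separate, modestly: the measured solubility of compound 2, 4900 nM, and of compound 3, 12200 nM, a 2.5-fold higher number (0.40 log units; beyond the scatter) With nothing else differing, that gap in solubility can be put down to this one stereocentre alone: the fact that compounds 2 and 3 differ only in the configuration as drawn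

As far as these compounds go, this rests on a single pair with a single ring, so whether the R configuration would behave the same way with the oxazolidinedione ring of compound 1 remains open. Also open, from the compounds shown here alone, is how the prostaglandin E2 receptor EP3 subtype assay and the physicochemical assay would respond to a carboxylic acid in place of the thiazolidinedione ring, with either configuration at the chain carbon.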